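The source may report more compounds than this note shows. Statements on the series, on what has been measured and on what is new or still open speak of the compounds shown alone.

Working notes on the series. Compound 1 `CCS(=O)(=O)Nc1cc(-c2ccc3ncnc(Nc4cccc(F)c4)c3c2)cnc1OC` gives 8020 nM in a functional assay on MCF7 cells (Homo sapiens) for cytotoxicity, read by sulforhodamine B assay, with a stated time of 72 h; on this read-out higher numbers stand for weaker inhibition and lower numbers for stronger inhibition. Compound 2 `CCS(=O)(=O)Nc1cc(-c2ccc3ncnc(Nc4ccc(OC)c(Cl)c4)c3c2)cnc1OC` gives 3320 nM, and compound 3 `CCS(=O)(=O)Nc1cc(-c2ccc3ncnc(Nc4ccc(F)c(C(=O)OC)c4)c3c2)cnc1OC` gives 1150 nM. Compound 3 stands lowest of the three numbers, with compound 2 nearest and compound 1 furthest. For the measured compounds named here, every measured step so far swaps the aryl group on the same nitrogen on an aromatic ring: a 2.4-fold lower number from compound 1 to compound 2 (0.38 log units; beyond the scatter), a 7.0-fold lower number from compound 1 to compound 3 (0.84 log units; beyond the scatter) and a 2.9-fold lower number from compound 2 to compound 3 (0.46 log units; beyond the scatter), each a modest step beyond the scatter.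

Compound 4 `CCS(=O)(=O)Nc1cc(-c2ccc3ncnc(Nc4ccc(C(=O)OC)c(OC)c4)c3c2)cnc1OC` is not yet measured. The change from compound 3 is 3-methoxy-4-(methoxycarbonyl)phenyl in place of 4-fluoro-3-(methoxycarbonyl)phenyl on a nitrogen on an aromatic ring. The methoxycarbonyl group stays but sits differently on the ring, and a methoxy group enters where a fluorine leaves. Going by the values given here, no measured step tests this exact exchange, so the three steps above give only the scale: modest moves in either direction. For compound 4 a modest step upward is expected, a 2.2-fold higher number from compound 3 to compound 4 (0.34 log units; beyond the scatter), since the grouping that gave compound 3 its low number is rearranged. The estimate for compound 4 in this assay is 2500 nM, within 600 nM to 10000 nM.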

Compound 4, half-maximal inhibitory concentration: 10900 nM
The estimate for compound 4 lay 4.4-fold (0.64 log units) below the measured number; measured number outside the range, above it.
By their numbers in this assay, from the lowest: compound 3; then compound 2; then compounds 1 and 4 (each within the scatter of the next).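

In this assay the presence of a methoxycarbonyl group on the aryl group does not by itself keep the number low: 4-fluoro-3-(methoxycarbonyl)phenyl and 3-methoxy-4-(methoxycarbonyl)phenyl both carry one, yet the exchange gives a 9.5-fold higher number from compound 3 to compound 4 (0.98 log units; beyond the scatter). The new aryl group also compares poorly with 3-chloro-4-methoxyphenyl, with a 3.3-fold higher number from compound 2 to compound 4 (0.52 log units; beyond the scatter), while a 1.4-fold higher number from compound 1 to compound 4 (0.13 log units; within the scatter) leaves it not separated from 3-fluorophenyl, which has no methoxycarbonyl group. Nothing available gives a reason for these steps.

The exchange relocates the methoxycarbonyl group and replaces fluorine with methoxy in a single step, and the compounds shown do not separate the two changes. They also leave open how a carboxylic acid or a primary amide in place of the methoxycarbonyl group would read on this aryl group.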